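This account rests on a few compounds, and the source may have more. Where it says the series, first, only, none or still open, it means among the compounds named here.

Measured compounds:
compound 1 `Cc1cc(O)c(C2=NN(c3ccc(S(N)(=O)=O)cc3)C(c3ccccc3Cl)C2)cc1Cl` — in a functional assay on CCRF-CEM cells (Homo sapiens) for antiproliferative activity, with a stated time of 48 h (a higher number here means a weaker inhibitor of growth, a lower number a stronger inhibitor of growth), compound 1 gives 4810 nM
compound 2 `COc1ccc(C2CC(c3cc(Cl)c(C)cc3O)=NN2c2ccc(S(N)(=O)=O)cc2)cc1OC` — in this assay compound 2 gives 5350 nM

Compound 2 stands highest of the two numbers, but its nearest neighbour is compound 1 and the step of a 1.1-fold higher number from compound 1 to compound 2 (0.05 log units; within the scatter) lies within the scatter, so the two compounds cannot be ordered on these data.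

Compound 3 `COc1ccc(C2CC(c3cc(Cl)c(C)cc3O)=NN2c2ccc(S(N)(=O)=O)cc2)c(OC)c1OC` is the next member. Relative to compound 2 the change is methoxy in place of hydrogen on an aromatic carbon. For the measured compounds named here, no measured step touches this exact change. Going by the values given here, the only step at hand, a 1.1-fold higher number from compound 1 to compound 2 (0.05 log units; within the scatter), exchanged the whole aryl group on the saturated ring carbon and left the number essentially unchanged, which suggests the group at that position is not the main driver of the read-out in this assay, at least between the two variants seen. On that basis the expectation for compound 3 is no step beyond the scatter, with the step from compound 2 to compound 3 estimated as a 1.0-fold higher number from compound 2 to compound 3 (0.01 log units; within the scatter). Compound 3 is expected to give about 5500 nM in this assay, with a range from 2500 nM to 12000 nM.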

Compound 3, concentration for 50% growth inhibition: 4510 nM
Compound 3: the middle estimate sits 1.2-fold (0.09 log units) above what was measured; measured number inside the range.
By their numbers in this assay, from the lowest: compounds 3, 1 and 2 (each within the scatter of the next).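

In this assay, the 3,4-dimethoxyphenyl to 2,3,4-trimethoxyphenyl change adds a methoxy group to an aromatic carbon, ortho to a large group and ortho to a methoxy group, and gives a 1.2-fold lower number from compound 2 to compound 3 (0.07 log units; within the scatter). For the compounds shown here, this is the first step that alters the aryl group on the saturated ring carbon without replacing it whole, and it shows that this added methoxy does not separate compound 3 from compound 2, while the whole-group exchange gives a 1.1-fold lower number from compound 1 to compound 3 (0.03 log units; within the scatter); the three aryl groups therefore cannot be ordered on these numbers. Nothing available explains why the number stays within the scatter across these changes.

From the compounds shown here alone, whether any group on this aryl ring moves the number beyond the scatter remains open, for example an amine or a carboxylic acid on the ring, or a longer chain in place of a methoxy group. The rest of the shared core is the same in all three compounds, so the contribution of its parts to growth inhibition cannot be read from this set.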